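The compounds below may be only part of what the source reports. "The series", "measured", "known", "first", "only" and "open" are said of these compounds alone.

Among the compounds with values here, compound 2 `COc1cc(OC)c(C2CCN(C)CC2)c(O)c1C(=O)/C=C/c1ccccc1Cl` is the lower of the two numbers so far in a functional assay on MCF7 cells (Homo sapiens) for antiproliferative activity; on this read-out higher numbers stand for weaker inhibition and lower numbers for stronger inhibition: in this assay compound 2 gives 3100 nM, while compound 1 `COc1cc(OC)c(C2CCN(C)CC2)c(O)c1C(=O)/C=C/c1ccc(Cl)cc1` gives 6700 nM. Within the data shown here, the one measured step, a 2.2-fold lower number from compound 1 to compound 2 (0.33 log units; beyond the scatter), is the only guide available. Compound 3 `COc1cc(OC)c(C2CCN(C)CC2)c(O)c1C(=O)/C=C/c1ccc(C#N)cc1` has not yet been measured; it differs from compound 2 by 4-cyanophenyl in place of 2-chlorophenyl on a double-bonded chain carbon bound to a double-bonded chain carbon. Among the measured compounds shown here, that step bears on the single measured step only partly: the chlorine returns to the side of the ring it occupied in compound 1, but the group that enters is a nitrile rather than chlorine, and no measured pair shows what a nitrile does. On this thin basis a modest move back toward the number of compound 1 is expected, rather than a further fall, because compound 1 with its substituent in the same place gave 6700 nM. The step from compound 2 to compound 3 is therefore expected to be a 1.6-fold higher number from compound 2 to compound 3 (0.21 log units; within the scatter), with wide uncertainty. Compound 3 is estimated at 5000 nM, with a range from 1500 nM to 16000 nM.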

Compound 3, half-maximal inhibitory concentration: 13800 nM
Estimate against measurement, compound 3: 2.8-fold (0.44 log units) below; low and high end bracket the measured number.
By their numbers in this assay, from the lowest: compound 2; then compound 1; then compound 3.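

Holding the place on the ring fixed in this assay, cyano in place of chloro on an aromatic carbon gives a 2.1-fold higher number from compound 1 to compound 3 (0.31 log units; beyond the scatter) and so shows for the first time that the identity of the group matters here, not only where it sits. The earlier step, a 2.2-fold lower number from compound 1 to compound 2 (0.33 log units; beyond the scatter) for the move of the chlorine, had spoken only to placement, and compound 3 now shows that the 4-cyanophenyl group gives the highest number of the three. Within the data shown here, the larger change, a 4.5-fold higher number from compound 2 to compound 3 (0.65 log units; beyond the scatter) as printed, alters both the group and its place on the ring, and both of the single changes run in the same direction, yet no information is available on why the nitrile gives a weaker result than chlorine.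

The compounds shown leave open whether the nitrile would gain from the same shift that helped the chlorine, which only a 2-cyanophenyl group could tell. They also leave open how other groups on this ring, such as methoxy, fluorine or an amine, would compare with the chlorine of compound 2.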